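A few compounds are considered here, and "the series" means these few. Any claim that something is new, unique, unknown or untested is made for them only; others in the source may bear on it.

In an ADME assay on Akata cells (Homo sapiens) for cytotoxicity (on this read-out lower numbers stand for higher toxicity in this test and higher numbers for lower toxicity in this test), compound 1 (`Nc1ncnc2c1ncn2/C=C1/C[C@H]1[C@H](O)CO`) gives 93500 nM while compound 2 (`Nc1ncnc2c1ncn2/C=C1\C[C@H]1[C@H](O)CO`) gives 72700 nM and compound 3 (`Nc1ncnc2c1ncn2/C=C1\C[C@@H]1[C@H](O)CO`) gives 57000 nM in the same test. Compound 3 therefore sits within the scatter of both neighbours, as the step (a 1.3-fold lower number from compound 2 to compound 3 (0.11 log units; within the scatter)) and the step (a 1.6-fold lower number from compound 1 to compound 3 (0.21 log units; within the scatter)) show. Compound 4 (`Nc1ncnc2c1ncn2/C=C1/C[C@@H]1[C@H](O)CO`) is related to compound 3 by a single change (the two compounds have the same atoms and bonds and differ only in configuration as drawn: 1 of 3 stereo elements differ; a double bond is drawn E in compound 3 and Z in compound 4) in which a double bond is drawn E in compound 3 and Z in compound 4. Among the compounds with values here, the closest precedent is the step (a 1.3-fold lower number from compound 1 to compound 2 (0.11 log units; within the scatter)), which concerns the same double bond, taken in the opposite sense, with the ring stereocentre drawn R. That step stays within the scatter, and so do the other two. Reversing it leans the estimate slightly towards a higher number, but no step beyond the scatter is expected in this assay here. The expected step is small (a 1.3-fold higher number from compound 3 to compound 4 (0.11 log units; within the scatter)) by this estimate. Compound 4 is expected near 73000 nM with an estimated range from 40000 nM to 130000 nM when it is measured.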

Compound 4, half-maximal cytotoxic concentration: 50500 nM
Compound 4: the middle estimate sits 1.4-fold (0.16 log units) above what was measured; the range from low to high includes it.
By their numbers in this assay, from the lowest: compounds 4, 3, 2 and 1 (each within the scatter of the next).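

With the ring stereocentre drawn S, the double bond geometry matters no more in this assay than it did with that centre drawn R: a 1.1-fold lower number from compound 3 to compound 4 (0.05 log units; within the scatter). The ring stereocentre, earlier changed on its own only with the double bond drawn E, has now been changed with the double bond drawn Z, and this step also stays within the scatter: a 1.9-fold lower number from compound 1 to compound 4 (0.27 log units; within the scatter). Changing both elements together again gives no step beyond the scatter (a 1.4-fold lower number from compound 2 to compound 4 (0.16 log units; within the scatter)), so all four combinations of these two elements lie within the scatter of one another in this test.

On these data alone, the third stereo element is drawn the same in all four compounds, and both hydroxyl groups are kept throughout, so the effect of changing that element remains open. As far as these compounds go, whether an amine or a carboxylic acid in place of a hydroxyl group, or a longer chain, would give a step beyond the scatter in this assay also remains open.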